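Cyclopentyloxy for Cyclopropylmethoxy on Two Pyridazinone Cores

The source may hold more compounds than are shown below. What is called first, only, known or untested is meant among the compounds shown, and "the series" means these compounds.

Four compounds share an aryl ether side chain and differ in the core and in one ether group. Compound 1 `COc1ccccc1OCCNc1ccc(=O)n(Cc2ccc(OC(F)F)c(OC3CCCC3)c2)n1` and compound 2 `COc1ccccc1OCCNc1ccc(=O)n(Cc2ccc(OC(F)F)c(OCC3CC3)c2)n1` were tested in a functional assay on SH-SY5Y cells (Homo sapiens) for antiproliferative activity, read by MTT assay, with a stated time of 48 h; a higher number here means a weaker inhibitor of growth, a lower number a stronger inhibitor of growth. In this assay compound 1 gives 9300 nM, and compound 2 gives 6300 nM. The step of a 1.5-fold higher number from compound 2 to compound 1 (0.17 log units; within the scatter), the change (cyclopentyl in place of cyclopropylmethyl on an oxygen on an aromatic ring), is within the scatter. Compound 3 `COc1ccccc1OCCNc1cnn(Cc2ccc(OC(F)F)c(OCC3CC3)c2)c(=O)c1Cl` carries a core that differs from that of compound 2; the difference between the two cores is not broken down here. In this assay compound 3 gives only a limit, > 100000 nM; this is the limit of > 100000 nM in this assay, at which 1 of the 3 values shown sits. Compound 4 `COc1ccccc1OCCNc1cnn(Cc2ccc(OC(F)F)c(OC3CCCC3)c2)c(=O)c1Cl` differs from compound 3 by the same change, (cyclopentyl in place of cyclopropylmethyl on an oxygen on an aromatic ring), so the change occurs twice among these compounds. Compound 4 is expected to stay at or near the same limit, with an estimate of 150000 nM and a range from 50000 nM to 500000 nM. This expectation rests on the step of a 1.5-fold higher number from compound 2 to compound 1 (0.17 log units; within the scatter), which is within the scatter, and on the limit of compound 3. The estimated step that the limit leaves unreadable from compound 3 to compound 4 is therefore expected to be small.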

Compound 4, concentration for 50% growth inhibition: > 100000 nM
Compound 4 ended at the assay's limit; the forecaster's own chance of this, stated with the estimate: 80%; the middle value is on the limit's open side.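

No step from compound 3 to compound 4 can be read, because each of the two compounds gives only a limit of the assay and not a number: the limit of > 100000 nM in this assay, at which 2 of the 4 values shown sit.

The compounds shown leave open whether cyclopentyl in place of cyclopropylmethyl changes growth inhibition at all on the core shared by compound 3 and compound 4.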